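A few compounds are considered here, and "the series" means these few. Any claim that something is new, unique, unknown or untested is made for them only; others in the source may bear on it.

Measured so far:
- Compound 1, `CN1CCN(c2nc3c(S(=O)(=O)c4cccc5ccccc45)cccc3o2)CC1`: 9.7 nM
- Compound 2, `CC(C)CN1CCN(c2nc3c(S(=O)(=O)c4cccc5ccccc45)cccc3o2)CC1`: 176 nM

Both were tested in an assay on HeLa cells for displacement of a labelled ligand from 5-hydroxytryptamine receptor 6 (Homo sapiens); on this read-out lower numbers stand for stronger inhibition and higher numbers for weaker inhibition. Compound 2 gives the higher of the two numbers: the step of an 18-fold higher number from compound 1 to compound 2 (1.26 log units; beyond the scatter) came with the isopropyl in place of hydrogen on the saturated chain carbon bound to the ring amine nitrogen, so the methyl of compound 1 became the isobutyl of compound 2.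

Compound 3, `O=S(=O)(c1cccc2ccccc12)c1cccc2oc(N3CCN(C4CCCC4)CC3)nc12`, is not yet measured. It differs from compound 2 in one place: cyclopentyl in place of isobutyl on an amine nitrogen in a ring. For the measured compounds named here, only the step from compound 1 to compound 2 bears on this change, and it showed that enlarging the group on this ring nitrogen from methyl to isobutyl cost a large amount. Cyclopentyl is again a large group at the same nitrogen, so compound 3 is expected to stay near compound 2 rather than return toward compound 1; the expected step of a 1.4-fold lower number from compound 2 to compound 3 (0.13 log units; within the scatter) is small and within the scatter. The estimate for compound 3 in this assay is therefore 130 nM, with a range from 40 nM to 450 nM.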

Compound 3, inhibition constant: 79 nM
The estimate for compound 3 lay 1.6-fold (0.22 log units) above the measured number; low and high end bracket the measured number.
By their numbers in this assay, from the lowest: compound 1; then compound 3; then compound 2.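

In this assay, replacing the open isobutyl with the ring of cyclopentyl on the same amine nitrogen gave a 2.2-fold lower number from compound 2 to compound 3 (0.35 log units; beyond the scatter), a modest step beyond the scatter, even though cyclopentyl has more heavy atoms than isobutyl; the number at this position therefore does not simply rise with the heavy-atom count, and compound 3 goes against that reading of the first step. The gain recovers only part of what was lost, as the comparison with the methyl group shows an 8.1-fold higher number from compound 1 to compound 3 (0.91 log units; beyond the scatter), so compound 1 still gives the lowest number of the three. Nothing shown here explains why the ring form gives the lower number.

The compounds shown leave open whether the change depends on the ring itself or on the branch sitting on the carbon bound to the nitrogen, a question that isopropyl or cyclopropyl at this nitrogen could address. They also leave open whether a smaller group such as ethyl, or the bare amine hydrogen, would give a number at or below that of compound 1, and whether a ring carrying an oxygen would behave like cyclopentyl.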